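Chloro in Place of Bromo: What to Expect

The compounds below may be only part of what the source reports. "The series", "measured", "known", "first", "only" and "open" are said of these compounds alone.

Compound 1 `Nc1nc(N)nc(-c2ccccc2Br)n1` is the starting point of this account. Within the data shown here, in a functional assay on the whole organism with Rattus norvegicus as the target, at a dose of 20 mg/kg by the intraperitoneal route (on this read-out lower numbers stand for less inhibition and higher numbers for more inhibition at the one dose given (going by the name of the read-out)), compound 1 gives 26%, the lowest of the three numbers measured so far. The nearest measured neighbour is compound 3 `Nc1nc(N)nc(-c2cc(Cl)ccc2Br)n1`, which in this assay gives 81%; the furthest is compound 2 `Nc1nc(N)nc(-c2ccc(Cl)cc2Br)n1`, which in this assay gives 96%. Both arise from compound 1 by the same kind of change, chloro in place of hydrogen on an aromatic carbon, and both steps are large and beyond the scatter: a number 70 percentage points higher from compound 1 to compound 2 (beyond the scatter) and a number 55 percentage points higher from compound 1 to compound 3 (beyond the scatter).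

Compound 4 `Nc1nc(N)nc(-c2ccccc2Cl)n1` has not yet been measured. It differs from compound 1 as follows: chloro in place of bromo on an aromatic carbon. This is a different kind of change from the two measured steps. Among the measured compounds shown here, in those, a chloro is added to the ring while the bromo stays in place; here the bromo itself is exchanged for chloro, and no measured pair shows an exchange of one halogen for another. The two measured steps therefore do not bear directly on this change, and the best expectation is a number close to that of compound 1. The expected step is a number 4 percentage points higher from compound 1 to compound 4 (within the scatter), a change not beyond the scatter. The estimate for compound 4 is 30%, with a range from 8% to 60%.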

Compound 4, a percentage reported as inhibition, in the whole organism at one dose (the size of the read-out at that dose, not a potency): 36%
Compound 4: middle estimate off by 6 percentage points, on the low side; the measured number falls inside the stated range.
By their numbers in this assay, from the lowest: compounds 1 and 4 (each within the scatter of the next); then compound 3; then compound 2.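

In this assay, exchanging the bromo for chloro on this aromatic carbon, ortho to a group of 8 heavy atoms, gives a number 10 percentage points higher from compound 1 to compound 4 (within the scatter). Among these compounds, the earlier compounds showed only what happens when a chloro is added elsewhere on the ring while the bromo stays in place, whereas this pair is the first to exchange the halogen at this position itself, and at the one dose given the read-out does not separate bromo from chloro here. No measurement shown offers an explanation for this result.

The compounds shown include only these two halogens at this position, so it remains open how a methyl group, a methoxy group or an amine in its place would read in this assay. On these data alone, it also remains open whether adding a second chloro to the ring of compound 4 would bring the same large gains that adding a chloro brought to compound 1, or whether those gains depend on the bromo being present.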